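The source may hold more compounds than are shown below. What is called first, only, known or untested is meant among the compounds shown, and "the series" means these compounds.

Measured so far in an ADME assay on HepG2 2.2.15 cells (Homo sapiens) for cytotoxicity; on this read-out higher numbers stand for lower toxicity in this test and lower numbers for higher toxicity in this test:
- compound 1, `O=C(Nc1ncc(C(Oc2ccc3cc(Br)ccc3c2)c2ccc(Cl)cc2)s1)c1cccs1`: "not toxic" (no number reported)
- compound 2, `COCCNc1ncc(C(Oc2ccc3cc(Br)ccc3c2)c2ccc(Cl)cc2)s1`: "not toxic" (no number reported)
- compound 3, `COc1ccc(C(=O)Nc2ncc(C(Oc3ccc4cc(Br)ccc4c3)c3ccc(Cl)cc3)s2)cc1`: > 50000 nM

Compound 1 is recorded in this assay as "not toxic" (no number reported) without a number. Compound 2 is recorded in the same way, as "not toxic" (no number reported). For compound 3 the read-out in this assay is a limit of the assay and not a number, > 50000 nM (the limit of > 50000 nM in this assay, at which 1 of the 3 values shown sits). Among the compounds with values here, none of the three compounds differs from another in a single place, so no step between measured compounds can be given; what the three entries show together is that no measurable cytotoxic concentration was reached for any of them. Compound 3 thus stands at the limit, alongside two entries that carry no number at all.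

Compound 4, `COc1ccc(C(=O)Nc2ncc(C(Nc3cccc4ccccc34)c3ccc(Cl)cc3)s2)cc1`, has not yet been measured. It differs from compound 3 in one place: (naphthalen-1-yl)amino in place of (6-bromonaphthalen-2-yl)oxy on a saturated chain carbon bound to two aromatic carbons. Within the data shown here, with no measured step to lean on and compound 3 itself at the limit, the expected step of a number no higher from compound 3 to compound 4 (the limit leaves the size open) is none beyond the usual scatter. Compound 4 is estimated at 50000 nM, with a range from 20000 nM to 100000 nM, and the result is expected most likely to be reported again only as a limit.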

Compound 4, half-maximal cytotoxic concentration: > 50000 nM
Compound 4 gave a limit, no number (the forecaster's own chance of this, stated with the estimate: 70%); the middle value lies on the limit itself.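

No step can be read from compound 3 to compound 4 in this assay, because both entries are limits of the assay and not numbers: the limit of > 50000 nM in this assay, at which 2 of the 4 values shown sit.

The compounds shown leave open whether (naphthalen-1-yl)amino in place of (6-bromonaphthalen-2-yl)oxy changes the half-maximal cytotoxic concentration at all; none of the four carries a number.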